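From methyl to cyclopropyl on an aromatic nitrogen

The source may report more compounds than this note shows. Statements on the series, on what has been measured and on what is new or still open speak of the compounds shown alone.

Compound 1 `COc1ccc(-c2cncc3[nH]c(=O)n(Cc4cc(OC)c(OC)c(OC)c4)c23)cc1O` reads > 20000 nM (a limit of the assay)
Compound 2 `COc1ccc(-c2cc3c(cn2)[nH]c(=O)n3-c2cc(OC)c(OC)c(OC)c2)cc1N` reads 820 nM
Compound 3 `COc1ccc(-c2cc3c(cn2)n(C)c(=O)n3-c2cc(OC)c(OC)c(OC)c2)cc1O` reads 1060 nM

All three results come from a functional assay on HCT-116 cells (Homo sapiens) for antiproliferative activity, read by MTT assay, with a stated time of 48 h (on this read-out lower numbers stand for stronger inhibition and higher numbers for weaker inhibition), and from no other test. Compound 1 gives > 20000 nM as a limit and not as a number. Compound 2 at 820 nM and compound 3 at 1060 nM lie within the scatter of each other, so these two cannot be told apart on the numbers.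

Compound 4 `COc1ccc(-c2cc3c(cn2)n(C2CC2)c(=O)n3-c2cc(OC)c(OC)c(OC)c2)cc1O` differs from compound 3 in one place. It has cyclopropyl in place of methyl on an aromatic nitrogen of a five-membered aromatic ring with 2 nitrogen, part of a fused or bridged system of two rings. The counted change is cyclopropyl in place of methyl on an aromatic nitrogen and the rest of the structure stays the same.

Among the measured compounds shown here, no pair of measured compounds shows this change alone, so this assay offers no direct precedent for it. A small step toward weaker inhibition is expected, perhaps none beyond the scatter, with compound 3 at 1060 nM as the starting point. The expected change is a 1.4-fold higher number from compound 3 to compound 4 (0.15 log units; within the scatter) on this reasoning. For compound 4 the estimated value is 1500 nM with 450 nM to 6000 nM as the expected range.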

Compound 4, half-maximal inhibitory concentration: > 20000 nM
Compound 4: only a limit was reported; the forecaster's own chance of this, stated with the estimate: 8%; middle value at least 13-fold (1.12 log units) from the limit.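

In this assay, this position on the aromatic nitrogen of the five-membered aromatic ring turns out not to be indifferent to what it carries: cyclopropyl in place of methyl gives an at least 18-fold higher number from compound 3 to compound 4 (1.27 log units; beyond the scatter), the only step at this position among the compounds shown and one that lies beyond the scatter. Compound 4 gives > 20000 nM, which is a limit of the assay and not a number. The step therefore marks the smallest loss of inhibition consistent with the data, while its true size stays unknown and no cause can be assigned to it: the limit of > 20000 nM in this assay, at which 2 of the 4 values shown sit.

The compounds shown leave open whether the loss follows from the three-membered ring itself or simply from the added carbon, a question that an ethyl or an isopropyl group on the same nitrogen would address. They also leave open how far this nitrogen accepts anything beyond methyl, such as a longer chain ending in a hydroxyl group or an amine, with the rest of compound 3 unchanged.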